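This account rests on a few compounds, and the source may have more. Where it says the series, first, only, none or still open, it means among the compounds named here.

Compound 3, whose structure is `CSc1ccccc1NC(=O)Nc1cc(C)nc2ccccc12`, gives 21000 nM in a physicochemical assay for solubility, at pH 7.4 (on this read-out higher numbers stand for higher solubility and lower numbers for lower solubility), the highest of the three numbers recorded. Its nearest neighbour on that scale is compound 1, `Cc1cc(NC(=O)Nc2ccc(C(=O)O)cc2)c2ccccc2n1`, which in this assay returns 9300 nM; compound 2, `Cc1cc(NC(=O)Nc2cccc(Cl)c2)c2ccccc2n1`, sits furthest away with 800 nM. The gaps from compound 3 to both of these lie beyond the ordinary scatter of the measurement.

Compound 4, `Cc1cc(NC(=O)Nc2ccccc2C(N)=O)c2ccccc2n1`, has not yet been measured. It differs from compound 3 in a single place: carbamoyl in place of methylsulfanyl on an aromatic carbon. Going by the values given here, no pair of compounds already measured differs in just one place, so no measured step can be laid beside this change. Judging only from the three numbers at hand, the step from compound 3 to compound 4 in this assay is expected to be small, either none beyond the scatter or a modest rise, as a 1.2-fold higher number from compound 3 to compound 4 (0.08 log units; within the scatter). Compound 4 is therefore expected to give about 25000 nM, within a range running from 8000 nM to 70000 nM.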

Compound 4, solubility: 200 nM
For compound 4 the middle estimate is 130-fold (2.10 log units) above the measured one; measured number outside the range, below it.
By their numbers in this assay, from the lowest: compound 4; then compound 2; then compound 1; then compound 3.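

In this assay the group on this aromatic carbon proves far from neutral: the swap gives a 110-fold lower number from compound 3 to compound 4 (2.02 log units; beyond the scatter) when carbamoyl takes the place of methylsulfanyl. Going by these compounds alone, this is the first pair that differs in one place, and it shows that a change at this single position, ortho to a large group, can move the read-out well beyond the scatter while the rest of the structure stays the same. Nothing at hand accounts for the size of this step.

On these data alone, whether a nitrile, a methoxy group or an amine on this same carbon would give a number closer to that of compound 3 or that of compound 4 remains open. Also open, as far as these compounds go, is whether the same swap elsewhere on this ring would give a step of similar size.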